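Replacing the Dichlorophenylamino Arm of Compound 2

The source may hold more compounds than are shown below. What is called first, only, known or untested is meant among the compounds shown, and "the series" means these compounds.

Measured compounds:
compound 1 `COc1cc(-c2nn(-c3cccc(NC(=O)Nc4cc(C(F)(F)F)cc(C(F)(F)F)c4)c3)cc2-c2ccncc2)ccc1Cl`: 829 nM
compound 2 `COc1cc(-c2nn(-c3cccc(NC(=O)Nc4ccc(Cl)c(Cl)c4)c3)cc2-c2ccncc2)ccc1Cl`: 965 nM
compound 3 `O=C(Nc1cccc(-n2cc(-c3ccncc3)c(-c3ccc(Cl)c(O)c3)n2)c1)Nc1ccc(Cl)c(Cl)c1`: 1340 nM

In a functional assay on SF-539 cells (Homo sapiens) for inhibition, read by sulforhodamine B assay, with a stated time of 48 h (a lower number here means a stronger inhibitor of growth, a higher number a weaker inhibitor of growth), compound 2 gives 965 nM, the second highest of the three numbers. Compound 1 gives 829 nM, which lies within the scatter of compound 2. Compound 3 gives 1340 nM, also within the scatter of compound 2. Compound 4 `COc1cc(-c2nn(-c3cccc(NC(=O)c4ccc(Cl)c(C(F)(F)F)c4)c3)cc2-c2ccncc2)ccc1Cl` carries 4-chloro-3-(trifluoromethyl)phenyl in place of (3,4-dichlorophenyl)amino on a carbonyl carbon. Within the data shown here, the one measured step, a 1.4-fold higher number from compound 2 to compound 3 (0.14 log units; within the scatter), concerns a different position and so does not bear on this change; the three numbers simply show that the whole set sits close together. Among the measured compounds shown here, with no step to lean on, the change is expected to move the number little beyond the scatter, so compound 4 is estimated at 1000 nM, in a range from 400 nM to 2500 nM. This estimate corresponds to an expected 1.0-fold higher number from compound 2 to compound 4 (0.02 log units; within the scatter).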

Compound 4, concentration for 50% growth inhibition: 4130 nM
Compound 4: the middle estimate sits 4.1-fold (0.62 log units) below what was measured; measured number above the stated range.
By their numbers in this assay, from the lowest: compounds 1, 2 and 3 (each within the scatter of the next); then compound 4.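

Among these compounds, the arm on this carbonyl carbon is not freely exchangeable: this assay shows a 4.3-fold higher number from compound 2 to compound 4 (0.63 log units; beyond the scatter), the only step so far that lies beyond the scatter. The change removes the amino nitrogen and its hydrogen-bond donor while also bringing in trifluoromethyl and losing one chlorine, so this single step cannot separate those differences. No measurement shown here explains the weaker growth inhibition. As far as these compounds go, it remains open how a (4-chloro-3-(trifluoromethyl)phenyl)amino arm would compare, since that group would keep the amino nitrogen and test the ring substituents alone.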